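This account rests on a few compounds, and the source may have more. Where it says the series, first, only, none or still open, it means among the compounds named here.

Values from a functional assay on RS4-11 cells (Homo sapiens) for inhibition, read by CCK-8 assay, with a stated time of 48 h; a lower number here means a stronger inhibitor, a higher number a weaker inhibitor:

- compound 1 `COc1ccc(S(=O)(=O)Oc2ccccc2/C=C(\C#N)C(=O)Nc2nnc(-c3cccs3)s2)cc1`: 4750 nM
- compound 2 `Cc1ccc(S(=O)(=O)Oc2cccc(/C=C(\C#N)C(=O)Nc3nnc(-c4cccs4)s3)c2)cc1`: > 20000 nM (a limit of the assay, not a number)
- compound 3 `COc1ccc(Cc2nnc(NC(=O)/C(C#N)=C/c3ccccc3OS(=O)(=O)c3ccc(OC)cc3)s2)cc1`: 840 nM

Of the two numeric values in this assay, the lower belongs to compound 3 at 840 nM, and compound 1 sits higher at 4750 nM. Compound 2 is reported only as a limit, > 20000 nM.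

The next compound is compound 4 `COc1ccc(Cc2nnc(NC(=O)/C(C#N)=C/c3ccccc3OS(=O)(=O)c3ccc([N+](=O)[O-])cc3)s2)cc1`, which carries nitro in place of methoxy on an aromatic carbon, para to a large group: nitro in place of methoxy on an aromatic carbon. Among the compounds with values here, no measured step touches this place. Within the data shown here, the only step available, a 5.7-fold lower number from compound 1 to compound 3 (0.75 log units; beyond the scatter), replaces thiophen-2-yl with 4-methoxybenzyl at a different place, so its size says little here. Among the measured compounds shown here, with no direct precedent, no direction can be assigned, and no step beyond the scatter is the central expectation, though with wide uncertainty. The expected step is a 1.2-fold higher number from compound 3 to compound 4 (0.08 log units; within the scatter). Compound 4 is estimated at 1000 nM, with an expected range from 250 nM to 4000 nM.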

Compound 4, half-maximal inhibitory concentration: 3670 nM
The estimate for compound 4 lay 3.7-fold (0.56 log units) below the measured number; the measured number falls inside the stated range.
By their numbers in this assay, from the lowest: compound 3; then compounds 4 and 1 (each within the scatter of the next). At a limit, above all of these: compound 2.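

In this assay, within the data shown here, the carbon para to a large group on the (4-methoxyphenyl)sulfonyl part had not been varied by the earlier compounds, and it turns out to matter: nitro in place of methoxy gives a 4.4-fold higher number from compound 3 to compound 4 (0.64 log units; beyond the scatter). That change works against the earlier gain, since it runs opposite in direction to a 5.7-fold lower number from compound 1 to compound 3 (0.75 log units; beyond the scatter), which was made at a different place, so the sulfonyl side as well as the other end of the molecule affects the number. Nothing in the data shown speaks to the cause of this step.

From the compounds shown here alone, with only methoxy and nitro at this carbon, two points do not define a trend, and it stays open whether an amine, a chlorine or plain hydrogen there would fall nearer compound 3 or compound 4. Going by these compounds, it is also open whether the nitro step would hold with thiophen-2-yl in place of 4-methoxybenzyl.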